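The compounds below may be only part of what the source reports. "The series", "measured", "known", "first", "only" and "open" are said of these compounds alone.

Measured so far in a functional assay, with a stated time of 20 min, tested at 50 uM; on this read-out lower numbers stand for a weaker effect and higher numbers for a stronger effect at the one concentration tested:
compound 1 `COc1cc(/C=C/C(=O)C2=C(/C=C/c3ccc(O)c(OC)c3)NC(=O)NC2c2ccccc2)ccc1O`, 40.2%
compound 2 `COc1cc(/C=C/C(=O)C2=C(/C=C/c3ccc(O)c(OC)c3)NC(=S)NC2c2ccccc2)ccc1O`, 48%
compound 3 `COc1cc(/C=C/C(=O)C2=C(/C=C/c3ccc(O)c(OC)c3)NC(=S)NC2c2ccc(C)cc2)ccc1O`, 62%

Compound 3 stands highest of the three numbers; compound 2 is nearest and compound 1 furthest, both beyond the scatter. Compound 4 `COc1cc(/C=C/C(=O)C2=C(/C=C/c3ccc(O)c(OC)c3)NC(=S)NC2c2ccccc2O)ccc1O` differs from compound 3 in one place: 2-hydroxyphenyl in place of 4-methylphenyl on a saturated ring carbon. Among the compounds with values here, the only measured step touching that ring is a number 14 percentage points higher from compound 2 to compound 3 (beyond the scatter), a modest rise from methyl in place of hydrogen on an aromatic carbon. Within the data shown here, no measured pair shows what a 2-hydroxyphenyl group does, so the expectation is uncertain; the working guess is that the gain seen for the methyl group is not kept and a modest downward step is expected, a number 12 percentage points lower from compound 3 to compound 4 (beyond the scatter). Compound 4 is therefore estimated at 50%, within 35% to 65%.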

Compound 4, a percentage reported as activity, at one concentration (the size of the read-out at that concentration, not a potency): 86.3%
Beside the measured number, compound 4's estimate is 36.3 percentage points below it; the measured number lies above the stated range.
By their numbers in this assay, from the lowest: compounds 1 and 2 (each within the scatter of the next); then compound 3; then compound 4.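

On the aromatic ring carried by the saturated ring carbon, the read-out in this assay responds to more than a methyl group: 2-hydroxyphenyl in place of 4-methylphenyl gives a number 24.3 percentage points higher from compound 3 to compound 4 (beyond the scatter). Measured against the unsubstituted phenyl, the 2-hydroxyphenyl group gives a number 38.3 percentage points higher from compound 2 to compound 4 (beyond the scatter), which exceeds a number 14 percentage points higher from compound 2 to compound 3 (beyond the scatter). Nothing available accounts for this rise.

As far as these compounds go, whether 2-methoxyphenyl or 2-aminophenyl would hold this level stays open. Also open, from the compounds shown here alone, is whether 2-hydroxyphenyl would give a similar rise on the core of compound 1.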